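Working notes: from compound 1 to compound 4

The compounds below may be only part of what the source reports. "The series", "measured", "known", "first", "only" and "open" are said of these compounds alone.

compound 1 `O=C1Nc2ccc(S(=O)(=O)N3CCOCC3)cc2/C1=N/c1ccc(O)cc1` – 27300 nM
compound 2 `COc1ccc(-c2c(C#N)c(N)n(/N=C3\C(=O)Nc4ccc(S(=O)(=O)N5CCOCC5)cc43)c(=O)c2C#N)cc1` – 18100 nM
compound 3 `O=C1Nc2ccc(S(=O)(=O)N3CCOCC3)cc2/C1=N/c1ccc(/N=C2\C(=O)Nc3ccc(S(=O)(=O)N4CCOCC4)cc32)cc1` – 7480 nM

These values come from a functional assay on HCT-116 cells (Homo sapiens) for cytotoxicity, read by sulforhodamine B assay, with a stated time of 24 h (on this read-out lower numbers stand for stronger inhibition and higher numbers for weaker inhibition), and set the starting point for the next step. Compound 1 (27300 nM) and compound 2 (18100 nM) lie within the scatter of each other. Compound 3 (7480 nM) is the only one set apart, with a number lower than that of compound 1 by more than the scatter.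

Compound 4 `CC(=O)c1cccc(/N=C2\C(=O)Nc3ccc(S(=O)(=O)N4CCOCC4)cc32)c1` carries 3-acetylphenyl in place of 4-hydroxyphenyl on a double-bonded nitrogen. Among the compounds with values here, no two measured compounds differ in one place only, so no measured step guides this one directly. No step beyond the scatter is expected in this assay. This expectation rests on compound 2 (18100 nM), which also differs from compound 1 on that nitrogen and stays within the scatter. Compound 3 (7480 nM) goes against this, so the range is kept wide.

The expected step is a 1.4-fold lower number from compound 1 to compound 4 (0.16 log units; within the scatter) and falls within the scatter.

Compound 4 is estimated at 19000 nM (expected range 7500 nM to 45000 nM).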

Compound 4, half-maximal inhibitory concentration: 29000 nM
Beside the measured number, compound 4's estimate is 1.5-fold (0.18 log units) below it; measured number inside the range.
By their numbers in this assay, from the lowest: compound 3; then compounds 2, 1 and 4 (each within the scatter of the next).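

In this assay, 3-acetylphenyl in place of 4-hydroxyphenyl on the double-bonded nitrogen gives a 1.1-fold higher number from compound 1 to compound 4 (0.03 log units; within the scatter), a step within the scatter. Within the data shown here, this is the first step between compounds that differ in one place only, and it shows that this exchange, which takes the count of hydrogen-bond donors in the group from one to none and adds a double bond outside the aromatic ring, gives numbers that cannot be told apart. Nothing measured here accounts for this result.

From the compounds shown here alone, it remains open whether an amine, a carboxylic acid or a longer chain in place of the acetyl group would produce a step beyond the scatter. Also open, going by these compounds, is which part of the larger group on that nitrogen in compound 3 goes with its value of 7480 nM in this assay.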